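Branching the Amide Chain of a Calpain-2 Inhibitor

The source may report more compounds than this note shows. Statements on the series, on what has been measured and on what is new or still open speak of the compounds shown alone.

Compound 1, `CCOC(=O)C(=O)C(CC)NC(=O)C(CC(C)C)NC(=O)OCc1ccccc1`: 400 nM
Compound 2, `CCCCOC(=O)C(=O)C(CC)NC(=O)C(CC(C)C)NC(=O)OCc1ccccc1`: 400 nM
Compound 3, `CCCCNC(=O)C(=O)C(CC)NC(=O)C(CC(C)C)NC(=O)OCc1ccccc1`: 50 nM

These three compounds were measured in an assay on isolated protein (Oryctolagus cuniculus) for inhibition of Calpain-2 catalytic subunit (Homo sapiens), at pH 8.0; on this read-out lower numbers stand for stronger inhibition and higher numbers for weaker inhibition. Compound 3 gives the lowest number of the set; the steps of an 8.0-fold lower number from compound 1 to compound 3 (0.90 log units; beyond the scatter) and an 8.0-fold lower number from compound 2 to compound 3 (0.90 log units; beyond the scatter) both lie beyond the scatter, so compound 3 is the strongest inhibitor measured here. Compound 4, `CCC(NC(=O)C(CC(C)C)NC(=O)OCc1ccccc1)C(=O)C(=O)NCC(C)C`, differs from it by isopropyl in place of propyl on a saturated chain carbon bound to an amide-type nitrogen, which read one bond further out is butylamino to isobutylamino. Among the compounds with values here, no measured step touches chain branching; the only chain change recorded, no change at the digits printed from compound 1 to compound 2 (within the scatter), left the number unchanged. A step no larger than the scatter is therefore expected: no change at the digits printed from compound 3 to compound 4 (within the scatter). Compound 4 is accordingly estimated at 50 nM, in a range from 20 nM to 150 nM.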

Compound 4, inhibition constant: 140 nM
Beside the measured number, compound 4's estimate is 2.8-fold (0.45 log units) below it; the range from low to high includes it.
By their numbers in this assay, from the lowest: compound 3; then compound 4; then compounds 1 and 2 (each within the scatter of the next).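

Same atoms, joined differently, are enough to shift the number at this position: isobutylamino in place of butylamino gives a 2.8-fold higher number from compound 3 to compound 4 (0.45 log units; beyond the scatter). Branching does not cancel the advantage of the amide over the esters, since isobutylamino in place of ethoxy gives a 2.9-fold lower number from compound 1 to compound 4 (0.46 log units; beyond the scatter), and in place of butoxy gives a 2.9-fold lower number from compound 2 to compound 4 (0.46 log units; beyond the scatter). Nothing available explains the cost of branching. As far as these compounds go, whether isopropylamino or a longer chain such as hexylamino on this carbonyl carbon would give a lower or a higher number stays open.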